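A Methyl Added to an Amide Nitrogen

The compounds below may be only part of what the source reports. "The series", "measured", "known", "first", "only" and "open" are said of these compounds alone.

Among the measured compounds shown here, compound 2 `CNC(=O)/C=C/c1ccncc1-c1ccc2ccccc2c1` is the one member of the set with a reported number: in a functional assay on HCT-116 cells (Homo sapiens) for inhibition, read by MTT assay, with a stated time of 72 h (on this read-out lower numbers stand for stronger inhibition of growth and higher numbers for weaker inhibition of growth), compound 2 gives 6550 nM. In this assay compound 1 `Cn1ncc2cc(-c3cnccc3/C=C/C(=O)N3CCOCC3)ccc21` gives "not determined" (no result reported), and compound 3 `Cn1ncc2ccc(-c3cnccc3/C=C/C(=O)N3CCOCC3)cc21` gives "not determined" (no result reported), so compound 2 cannot be ranked against anything and simply stands alone. Compound 4 `CN(C)C(=O)/C=C/c1ccncc1-c1ccc2ccccc2c1` differs from compound 2 by a single change, (methyl in place of hydrogen on an amide-type nitrogen). For the measured compounds named here, no measured pair shows what this change does here, so nothing beyond the usual scatter can be claimed with confidence. A modest weakening is nonetheless estimated, a 1.3-fold higher number from compound 2 to compound 4 (0.11 log units; within the scatter). Compound 4 is therefore expected to give about 8500 nM, within an estimated range of 2800 nM to 26000 nM.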

Compound 4, concentration for 50% growth inhibition: 4540 nM
For compound 4 the middle estimate is 1.9-fold (0.27 log units) above the measured one; the measured number falls inside the stated range.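

Among the compounds shown here, this pair gives the first reading at this position: in this assay, the step is a 1.4-fold lower number from compound 2 to compound 4 (0.16 log units; within the scatter). Replacing the amide hydrogen with methyl on this amide-type nitrogen therefore leaves the growth-inhibition number of compound 4 indistinguishable from that of compound 2, so a hydrogen on this nitrogen is not required to retain this level of activity. Nothing available explains this result. On these data alone, whether an ethyl group or a longer chain on this nitrogen would behave the same way remains open. So does the effect of replacing the whole amide with a carboxylic acid.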